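The source may hold more compounds than are shown below. What is called first, only, known or untested is meant among the compounds shown, and "the series" means these compounds.

Three compounds of this series have been run through a physicochemical assay for solubility, with a stated time of 4 h, at pH 7.4; a lower number here means a less soluble compound, a higher number a more soluble compound. Compound 1, `CNC(=O)c1cc(N)c(Nc2ccc(C#N)cc2)cc1Oc1c(C)cc(CCC#N)cc1C`, gives 8.28 ug/mL. Compound 2, `Cc1cc(CCC#N)cc(C)c1Oc1cc(Nc2ccc(C#N)cc2)c(N)cc1CO`, gives 18.8 ug/mL in this assay. Compound 3, `Cc1cc(/C=C/C#N)cc(C)c1Oc1cc(Nc2ccc(C#N)cc2)c(N)cc1CO`, gives 3.23 ug/mL in this assay and stands lowest of the three, both gaps beyond the scatter.

Two single changes connect these numbers. From compound 2 to compound 1 the change is methylcarbamoyl in place of hydroxymethyl on an aromatic carbon, and the result is a 2.3-fold lower number from compound 2 to compound 1 (0.36 log units; beyond the scatter). Compound 2 and compound 3 differ by one change on the core, and the result is a 5.8-fold lower number from compound 2 to compound 3 (0.76 log units; beyond the scatter). Compound 1 and compound 3 are not joined by a single change; their two values simply show compound 3 lower.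

Compound 4, `CNC(=O)c1cc(N)c(Nc2ccc(C#N)cc2)cc1Oc1c(C)cc(/C=C/C#N)cc1C`, has not yet been measured in this assay. It differs from compound 3 by methylcarbamoyl in place of hydroxymethyl on an aromatic carbon. This is the same change, at the same place, as that from compound 2 to compound 1; the cores of the two pairs differ by 2-cyanoethenyl in place of 2-cyanoethyl on an aromatic carbon.

The expectation for compound 4 rests on a single earlier instance: because the step of a 2.3-fold lower number from compound 2 to compound 1 (0.36 log units; beyond the scatter) was modest but beyond the scatter, a step of comparable size is expected here, a 2.3-fold lower number from compound 3 to compound 4 (0.36 log units; beyond the scatter). For the measured compounds named here, with only one pair as a basis, the range is kept wide. Compound 4 is therefore estimated at 1.4 ug/mL in this assay, with a likely span from 0.6 ug/mL to 3.5 ug/mL.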

Compound 4, solubility: 1.32 ug/mL
Compound 4: the middle estimate sits 1.1-fold (0.03 log units) above what was measured; the range from low to high includes it.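

In this assay methylcarbamoyl in place of hydroxymethyl on an aromatic carbon gives a 2.4-fold lower number from compound 3 to compound 4 (0.39 log units; beyond the scatter) on the core carrying 2-cyanoethenyl and a 2.3-fold lower number from compound 2 to compound 1 (0.36 log units; beyond the scatter) on the core carrying 2-cyanoethyl, so the change runs in the same direction and with nearly the same printed size on both cores, and the second change also repeats, with a 6.3-fold lower number from compound 1 to compound 4 (0.80 log units; beyond the scatter) against a 5.8-fold lower number from compound 2 to compound 3 (0.76 log units; beyond the scatter) on the other pair. These four compounds form a single square, so the two changes combine with little departure from simple addition here, but this rests on two cores only and does not show that the change would carry to a core with any other group in that place. Nothing measured here bears on why the number falls with either change.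

Still open, on these data alone, is whether an amine or a carboxylic acid in place of hydroxymethyl on that aromatic carbon would follow the same order on both cores. As far as these compounds go, it is equally open whether a longer chain in place of 2-cyanoethyl or 2-cyanoethenyl would leave the step from hydroxymethyl to methylcarbamoyl at a similar size.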